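A few compounds are considered here, and "the series" means these few. Any claim that something is new, unique, unknown or untested is made for them only; others in the source may bear on it.

Compound 1 `CNC[C@@H]1CCN(c2cc3c(cc2F)c(=O)c(C(=O)O)cn3Cc2ccc(-c3ccccc3)cc2)C1`: 168000 nM
Compound 2 `CNCCNc1cc2c(cc1F)c(=O)c(C(=O)O)cn2Cc1ccc(-c2ccccc2)cc1`: > 200000 nM
Compound 3 `O=C(O)c1cn(Cc2ccc(-c3ccccc3)cc2)c2cc(NC[C@@H]3CCNC3)c(F)cc2c1=O`: 104000 nM

In an assay on isolated protein for inhibition of DNA topoisomerase 1 (Homo sapiens), with a stated time of 15 min (a higher number here means a weaker inhibitor, a lower number a stronger inhibitor), compound 3 gives 104000 nM, the lowest of the two numbers shown. Its nearest neighbour is compound 1, with a 1.6-fold lower number from compound 1 to compound 3 (0.21 log units; within the scatter), so the two cannot be set in order. Compound 2 gives only a limit of this assay, > 200000 nM, the limit described in the limit of > 200000 nM in this assay, at which 1 of the 3 values shown sits.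

Compound 4 `NCCNc1cc2c(cc1F)c(=O)c(C(=O)O)cn2Cc1ccc(-c2ccccc2)cc1` differs from compound 3 by aminomethyl in place of pyrrolidin-3-yl on a saturated chain carbon bound to a nitrogen on an aromatic ring. Among the compounds with values here, the measured step that bears on this is the one from compound 2 to compound 3, an at least 1.9-fold lower number from compound 2 to compound 3 (0.28 log units; that floor lies within the scatter), where a chain bearing a methylamino group was replaced by the ring that compound 4 now loses. Going back to an open chain, here aminomethyl, brings compound 4 close to compound 2 in shape, so the number is expected to move up, toward the limit, by a 1.8-fold higher number from compound 3 to compound 4 (0.26 log units; within the scatter). The step from compound 1 to compound 2, an at least 1.1-fold higher number from compound 1 to compound 2 (0.07 log units; that floor lies within the scatter), points the same way but is only a floor.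

Compound 4 is therefore estimated at 190000 nM in this assay, with a range from 90000 nM to 400000 nM, and a fair chance that only a limit is reported.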

Compound 4, half-maximal inhibitory concentration: 72800 nM
Estimate against measurement, compound 4: 2.6-fold (0.42 log units) above; the whole stated range lies above it.
By their numbers in this assay, from the lowest: compounds 4, 3 and 1 (each within the scatter of the next, the first and the last beyond it). At a limit, above all of these: compound 2.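

In this assay, pyrrolidin-3-yl can give way to aminomethyl on a saturated chain carbon bound to a nitrogen on an aromatic ring with no change that can be read, a 1.4-fold lower number from compound 3 to compound 4 (0.15 log units; within the scatter), so the ring is not needed here to hold the number at this level. The open chain does respond at its amine: with hydrogen in place of methyl on an amine nitrogen, the result is an at least 2.7-fold lower number from compound 2 to compound 4 (0.43 log units; beyond the scatter), and the exchange of the 3-((methylamino)methyl)pyrrolidin-1-yl group for (2-aminoethyl)amino gives a 2.3-fold lower number from compound 1 to compound 4 (0.36 log units; beyond the scatter), both beyond the scatter and both modest in size. The first of these two steps is only a floor, as compound 2 stands at a limit: the limit of > 200000 nM in this assay, at which 1 of the 4 values shown sits.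

The compounds shown leave open whether a longer chain, such as 3-aminopropyl, or a dimethylamino group at the end of the chain would keep the number of compound 4. They also leave open whether hydrogen in place of methyl on the amine of compound 1 would give a step of similar size.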